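A few compounds are considered here, and "the series" means these few. Any claim that something is new, unique, unknown or untested is made for them only; others in the source may bear on it.

In a functional assay on U-937 cells (Homo sapiens) (a higher number here means a weaker inhibitor, a lower number a stronger inhibitor), compound 1 `COc1cc(C(=O)NS(=O)(=O)c2ccccc2C)ccc1Cc1c[nH]c2ccc(NC(=O)OC3CCCC3)cc12` gives 2 nM. Going by the values given here, compound 2 `COc1cc(C(=O)NS(=O)(=O)c2ccccc2C)ccc1Cc1cn(C(=O)NCCCc2ccccc2)c2ccc(NC(=O)OC3CCCC3)cc12` gives 0.1 nM, the lower of the two numbers so far. Compound 3 `COc1cc(C(=O)NS(=O)(=O)c2ccccc2C)ccc1Cc1cn(C(=O)N2CCOCC2)c2ccc(NC(=O)OC3CCCC3)cc12` has morpholin-4-yl in place of (3-phenylpropyl)amino on a carbonyl carbon, a change counted as morpholin-4-yl in place of (3-phenylpropyl)amino on a carbonyl carbon. Among the compounds with values here, only one measured step bears on this: a 20-fold lower number from compound 1 to compound 2 (1.30 log units; beyond the scatter), a large step beyond the scatter, which put (3-phenylpropyl)carbamoyl in place of hydrogen on an aromatic nitrogen. Within the data shown here, no measured compound separates the carbonyl from the (3-phenylpropyl)amino that compound 3 gives up, so it is expected to keep only part of that gain. A moderate move toward a higher number is therefore expected, with the estimated step being a 5.0-fold higher number from compound 2 to compound 3 (0.70 log units; beyond the scatter). For compound 3 the estimate is 0.5 nM, with an expected range from 0.1 nM to 2.5 nM.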

Compound 3, half-maximal inhibitory concentration: 2 nM
Compound 3: the middle estimate sits 4.0-fold (0.60 log units) below what was measured; measured number inside the range.
By their numbers in this assay, from the lowest: compound 2; then compounds 1 and 3 (each within the scatter of the next).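

In this assay, the change on the carbonyl carbon is decisive: morpholin-4-yl in place of (3-phenylpropyl)amino gives a 20-fold higher number from compound 2 to compound 3 (1.30 log units; beyond the scatter). Set against the parent without any group on the aromatic nitrogen, the morpholine amide shows no change at the digits printed from compound 1 to compound 3 (within the scatter), so a carbonyl on that nitrogen does not by itself carry the gain; what is attached to the carbonyl matters. The data shown give no measured explanation for this difference.

As far as these compounds go, the swap replaces the phenyl ring, the propyl chain and the amide hydrogen at once, so it remains open which of these matters. Benzylamino would test a shorter chain, while piperidin-1-yl would test another ring without the chain or the amide hydrogen.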